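Replacing Fluoro with Hydroxy on the Propyl Chain

The source may hold more compounds than are shown below. What is called first, only, known or untested is meant among the compounds shown, and "the series" means these compounds.

- Compound 1 `CCCn1nc(C(=O)N[C@H]2COc3ccccc3N(C)C2=S)nc1Cc1ccccc1`: 288 nM
- Compound 2 `CC(C)n1nc(C(=O)N[C@H]2COc3ccccc3N(C)C2=S)nc1Cc1ccccc1`: 360 nM
- Compound 3 `CN1C(=S)[C@@H](NC(=O)c2nc(Cc3ccccc3)n(CCCF)n2)COc2ccccc21`: 4760 nM

In a functional assay on HT-29 cells (Homo sapiens) for inhibition, read by luminescence and CellTiter-Glo, with a stated time of 24 h (a lower number here means that less compound is needed, a higher number that more compound is needed for the effect), compound 3 has the highest number of the three, so it needs the most compound for the effect. Compound 4 `CN1C(=S)[C@@H](NC(=O)c2nc(Cc3ccccc3)n(CCCO)n2)COc2ccccc21` differs from it in one place: hydroxy in place of fluoro on a saturated chain carbon, three bonds along the chain from an aromatic nitrogen. Hydroxy stands in place of fluoro on a saturated chain carbon, three bonds along the chain from an aromatic nitrogen. Within the data shown here, no measured compound carries hydroxy there. The closest evidence is the large step on adding fluoro, a 17-fold higher number from compound 1 to compound 3 (1.22 log units; beyond the scatter), and the similarly large a 13-fold higher number from compound 2 to compound 3 (1.12 log units; beyond the scatter). Neither shows what hydroxy does, so a number near that of compound 3 is expected, with no step beyond the scatter. The expected step is a 1.3-fold higher number from compound 3 to compound 4 (0.10 log units; within the scatter). For compound 4, the estimated value is 6000 nM, within an expected range of 1500 nM to 25000 nM.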

Compound 4, half-maximal effective concentration: 209 nM
Beside the measured number, compound 4's estimate is 29-fold (1.46 log units) above it; the whole stated range lies above it.
By their numbers in this assay, from the lowest: compounds 4, 1 and 2 (each within the scatter of the next); then compound 3.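

At this place on the chain, the choice of group matters greatly in this assay: hydroxy in place of fluoro gives a large step (a 23-fold lower number from compound 3 to compound 4 (1.36 log units; beyond the scatter)), while hydroxy in place of hydrogen (a 1.4-fold lower number from compound 1 to compound 4 (0.14 log units; within the scatter)) and 3-hydroxypropyl in place of isopropyl (a 1.7-fold lower number from compound 2 to compound 4 (0.24 log units; within the scatter)) both stay within the scatter. The large penalty seen with fluoro is therefore not shared by hydroxy, and compound 4 stands level with compound 1 and compound 2. Nothing measured here explains this difference. Still open, going by these compounds, is whether an amine or a carboxylic acid at this place, or a longer chain carrying hydroxy, would behave like hydroxy or like fluoro.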